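This account rests on a few compounds, and the source may have more. Where it says the series, first, only, none or still open, it means among the compounds named here.

Compound 2 `CCCc1nnc(SCC(=O)c2ccc(Cl)cc2)n1N1C(=O)c2ccccc2C1=O` carries a (4-chlorophenyl)carbonyl group on a saturated chain carbon bound to a sulfur, attached to the shared core. In a functional assay on MKN-45 cells (Homo sapiens) for cytotoxicity, read by MTT assay, with a stated time of 48 h (a higher number here means a weaker inhibitor, a lower number a stronger inhibitor), compound 2 gives > 200000 nM, which is a limit of the assay and not a number. Its measured relative, compound 1 `CCCc1nnc(SCc2ccccc2)n1N1C(=O)c2ccccc2C1=O`, has a phenyl on that same saturated chain carbon bound to a sulfur. In this assay compound 1 gives > 200000 nM, likewise a limit and not a number. The step that the two limits leave unreadable from compound 1 to compound 2 cannot be read because the limit of > 200000 nM in this assay, at which 2 of the 2 values shown sit, leaves no number on either side.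

Compound 3 `CCCc1nnc(SCC(=O)c2ccccc2)n1N1C(=O)c2ccccc2C1=O` differs from compound 2 by one change: hydrogen in place of chloro on an aromatic carbon, a hydrogen in place of chloro on an aromatic carbon, para to a large group; cut one bond further out, this reads as (4-chlorophenyl)carbonyl to benzoyl. Within the data shown here, no measured step bears on this change, since the only measured step is unreadable. The expected step is a number no higher from compound 2 to compound 3 (the limit leaves the size open), which would leave compound 3 at the limit as well. Compound 3 is estimated at 200000 nM, within 100000 nM to 400000 nM.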

Compound 3, half-maximal inhibitory concentration: > 200000 nM
Compound 3: a limit, no number; the forecaster's own chance of this, stated with the estimate: 85%; the middle value lies on the limit itself.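

The steps from compound 2 to compound 3 and from compound 1 to compound 3 cannot be read, because neither side of either step has a number, only a limit: the limit of > 200000 nM in this assay, at which 3 of the 3 values shown sit.

The compounds shown leave open whether swapping chloro for hydrogen, or phenyl for benzoyl, changes the result in this assay at all.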